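This account rests on a few compounds, and the source may have more. Where it says the series, first, only, none or still open, it means among the compounds named here.

Working notes, values in an ADME assay on microsomes from liver (Homo sapiens) for metabolic stability, read by LC-MS, using NADPH, with stated times of 5 min and 30 min, tested at 1 uM; a higher number here means faster removal of the compound, a lower number slower removal:

- compound 1 `C[C@@H]1CC(=O)N(c2cnc(NCc3c(F)ccc4c3CCO4)n3cnnc23)C1`: < 3 mL.min-1.g-1
- compound 2 `CN(C)Cc1ccc(C(=O)Nc2cnc(NCc3c(F)ccc4c3CCO4)n3cnnc23)cc1`: 13 mL.min-1.g-1
- compound 3 `CN(c1ccccc1)c1cnc(NCc2c(F)ccc3c2CCO3)n2cnnc12`: 55 mL.min-1.g-1

The entry for compound 1 is a limit of the assay, not a number. Compound 3 stands highest of the three. Compound 4 `O=C(Nc1cnc(NCc2c(F)ccc3c2CCO3)n2cnnc12)c1cccnc1` carries ((pyridin-3-yl)carbonyl)amino in place of methyl(phenyl)amino on an aromatic carbon. Going by the values given here, the one measured step at this place, an at least 18-fold higher number from compound 1 to compound 3 (1.26 log units; beyond the scatter), is large and ends on methyl(phenyl)amino. The nearest measured analogue is compound 2, also a carbonyl amino compound, at 13 mL.min-1.g-1. A lower number in this assay is therefore expected, beyond the scatter but moderate in size: a 3.9-fold lower number from compound 3 to compound 4 (0.59 log units; beyond the scatter) is the expected step. For compound 4 the estimate is 14 mL.min-1.g-1, with an expected range of 5 mL.min-1.g-1 to 38 mL.min-1.g-1.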

Compound 4, intrinsic clearance in microsomes: < 3 mL.min-1.g-1
Compound 4: only a limit was reported; the forecaster's own chance of this, stated with the estimate: 12%; middle value at least 4.6-fold (0.66 log units) from the limit.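

In this assay, ((pyridin-3-yl)carbonyl)amino in place of methyl(phenyl)amino gives an at least 18-fold lower number from compound 3 to compound 4 (1.26 log units; beyond the scatter). With the carbonyl amino link kept, pyridin-3-yl in place of 4-((dimethylamino)methyl)phenyl on the carbonyl carbon gives an at least 4.3-fold lower number from compound 2 to compound 4 (0.63 log units; beyond the scatter), so the group on that carbonyl carbon also matters at this place. The step between compound 1 and compound 4 cannot be read, and the number for compound 4 is only a limit: the limit of < 3 mL.min-1.g-1 in this assay, at which 2 of the 4 values shown sit.

Open, as far as these compounds go, is whether an unsubstituted phenyl on the carbonyl carbon also reaches this limit. Also open, from the compounds shown here alone, is how a morpholine on the same aromatic carbon would compare.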